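The compounds below may be only part of what the source reports. "The series", "measured", "known", "first", "only" and "open" are said of these compounds alone.

Measured compounds:
- compound 1 `COc1ccc(-c2cn3cc(C4=CCN(C(=O)C(C)(C)C)CC4)ccc3n2)cc1OC`, in a functional assay on A549 cells (Homo sapiens) for antiproliferative activity, read by MTT assay, with a stated time of 48 h (on this read-out lower numbers stand for stronger inhibition and higher numbers for weaker inhibition), compound 1 gives 4340 nM
- compound 2 `COc1ccc(-c2cn3cc(C4=CCN(S(=O)(=O)C5CCCCC5)CC4)ccc3n2)cc1OC`, compound 2 gives 4490 nM
- compound 3 `COc1ccc(-c2cn3cc(C4=CCN(C(=O)c5cccc(C(F)(F)F)c5)CC4)ccc3n2)cc1OC`, compound 3 gives 3690 nM

Compound 1 stands second highest of the three numbers, with all three lying within the scatter of one another: a 1.0-fold higher number from compound 1 to compound 2 (0.01 log units; within the scatter), a 1.2-fold lower number from compound 1 to compound 3 (0.07 log units; within the scatter) and a 1.2-fold lower number from compound 2 to compound 3 (0.09 log units; within the scatter). The change from compound 1 to compound 4 `COc1ccc(-c2cn3cc(C4=CCN(C(=O)c5cccs5)CC4)ccc3n2)cc1OC` is thiophen-2-yl in place of tert-butyl on a carbonyl carbon. Of the measured steps, the one that bears on it is the step from compound 1 to compound 3, where an aromatic ring likewise replaced tert-butyl on the carbonyl carbon, and that step stayed within the scatter; the step from compound 1 to compound 2, which exchanges the whole amide for a sulfonamide, also stayed within the scatter. On these three compounds, the group on the carbonyl carbon has not moved this assay beyond its scatter, so no step beyond the scatter is expected for compound 4. Compound 4 is therefore expected to come out near compound 1, at 4000 nM (range 1600 nM to 10000 nM), which would be a step of a 1.1-fold lower number from compound 1 to compound 4 (0.04 log units; within the scatter).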

Compound 4, half-maximal inhibitory concentration: 5200 nM
Compound 4: the middle estimate sits 1.3-fold (0.11 log units) below what was measured, and the stated range covers the measured number.
By their numbers in this assay, from the lowest: compounds 3, 1, 2 and 4 (each within the scatter of the next).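

In this assay, the thiophen-2-yl group on the carbonyl carbon, with its five-membered aromatic ring and one hetero atom, leaves the number within the scatter of both earlier groups there: the result is a 1.2-fold higher number from compound 1 to compound 4 (0.08 log units; within the scatter) and a 1.4-fold higher number from compound 3 to compound 4 (0.15 log units; within the scatter). Replacing the cyclohexylsulfonyl group with (thiophen-2-yl)carbonyl on the ring nitrogen gives a 1.2-fold higher number from compound 2 to compound 4 (0.06 log units; within the scatter), so a hetero atom in the ring on the carbonyl carbon adds no step beyond the scatter on these four compounds. No measurement shown here accounts for this flat picture.

Going by these compounds, whether a basic amine such as a piperazine, or a carboxylic acid, on the carbonyl carbon would move the number beyond the scatter remains open. On these data alone, all four compounds share the same core, so the effect of a change there also remains open.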